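Adding a methyl to the ring nitrogen of compound 2

The compounds below may be only part of what the source reports. "The series", "measured", "known", "first", "only" and "open" are said of these compounds alone.

In a functional assay on A549 cells (Homo sapiens) for antiproliferative activity, read by MTT assay, with a stated time of 48 h (on this read-out higher numbers stand for weaker inhibition and lower numbers for stronger inhibition), compound 2 (`COc1ccc(-c2cc3c(cn2)[nH]c(=O)n3-c2cc(OC)c(OC)c(OC)c2)cc1O`) gives 630 nM. Compound 1 (`COc1ccc(-c2cc3c(cn2)[nH]c(=O)n3-c2cc(OC)c(OC)c(OC)c2)cc1`) gives 1120 nM, and the step is a 1.8-fold lower number from compound 1 to compound 2 (0.25 log units; within the scatter). Compound 3 (`CCOc1ccc(-c2cc3c(cn2)[nH]c(=O)n3-c2cc(OC)c(OC)c(OC)c2)cc1F`) gives 2540 nM, and the step is a 4.0-fold higher number from compound 2 to compound 3 (0.61 log units; beyond the scatter). Compound 2 therefore stands at the low end of the numbers, level with compound 1 within the scatter.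

Compound 4 (`COc1ccc(-c2cc3c(cn2)n(C)c(=O)n3-c2cc(OC)c(OC)c(OC)c2)cc1O`) differs from compound 2 in one place: methyl in place of hydrogen on an aromatic nitrogen. This is methyl in place of hydrogen on an aromatic nitrogen. Within the data shown here, none of the measured steps touches that nitrogen, since all of them alter the phenyl group on the core. The other measured step, a 2.3-fold higher number from compound 1 to compound 3 (0.36 log units; beyond the scatter), is also modest, so these steps only hint at how much this assay can move with a small change. They give no direction for this one. The expected result is therefore a 1.1-fold higher number from compound 2 to compound 4 (0.05 log units; within the scatter), which amounts to no firm change, with wide uncertainty. Compound 4 is estimated at 700 nM, with an expected range from 200 nM to 2500 nM.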

Compound 4, half-maximal inhibitory concentration: 3520 nM
The estimate for compound 4 lay 5.0-fold (0.70 log units) below the measured number; the measured number lies above the stated range.
By their numbers in this assay, from the lowest: compounds 2 and 1 (each within the scatter of the next); then compounds 3 and 4 (each within the scatter of the next).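

In this assay, among these compounds, the earlier steps all altered the phenyl group on the shared core, so they said nothing about the ring nitrogen. The new step, a 5.6-fold higher number from compound 2 to compound 4 (0.75 log units; beyond the scatter), shows that this nitrogen is sensitive to change: a single added carbon, replacing the hydrogen there, is enough to move the number beyond the usual scatter, towards weaker inhibition. No measurement at hand explains this step.

The compounds shown leave open whether an ethyl chain, or a longer chain ending in an amine or a carboxylic acid, would behave as the methyl does at this nitrogen. They also leave open whether the same methyl would move the numbers of compound 1 and compound 3, which carry different phenyl groups, by a similar amount.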